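This account rests on a few compounds, and the source may have more. Where it says the series, first, only, none or still open, it means among the compounds named here.

Measured in a functional assay on HEK293 cells (Homo sapiens) for cytotoxicity; on this read-out higher numbers stand for lower toxicity in this test and lower numbers for higher toxicity in this test:
- Compound 1 `COc1ccc([C@H]2CC(=O)N(c3cccc(NCC4CCOC4)c3)C2)cc1OC1CCCC1`: > 10000 nM
- Compound 2 `COc1ccc([C@H]2CC(=O)N(c3cccc(NS(=O)(=O)c4cc(C)ccc4OC)c3)C2)cc1OC1CCCC1`: > 10000 nM

Compound 2 gives > 10000 nM, which is a limit of the assay and not a number. Among the measured compounds shown here, the same is true of the only other compound measured, so compound 2 cannot be placed on a scale, and all that can be said is the limit of > 10000 nM in this assay, at which 2 of the 2 values shown sit.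

Compound 3 `COc1ccc([C@H]2CC(=O)N(c3cccc(NS(=O)(=O)c4cccc(Cl)c4C)c3)C2)cc1OC1CCCC1` keeps the shared core and changes one group, with 3-chloro-2-methylphenyl in place of 2-methoxy-5-methylphenyl on a sulfonyl sulfur.

For the measured compounds named here, the one measured step, a step that the two limits leave unreadable from compound 1 to compound 2, involves a different exchange and gives no size to carry over. The expectation for compound 3 therefore rests only on compound 1 and compound 2 sharing one limit in this assay, and it is likely to reach that limit too. The expected change is a number no higher from compound 2 to compound 3 (the limit leaves the size open), with no shift beyond the scatter foreseen in either direction. Compound 3 is estimated at 10000 nM, with an expected range from 5000 nM to 20000 nM.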

Compound 3, half-maximal cytotoxic concentration: > 10000 nM
Compound 3: a limit, no number; the forecaster's own chance of this, stated with the estimate: 80%; the middle value lies on the limit itself.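

The steps linking compound 3 to compound 1 and compound 2 cannot be read, because all three compounds stop at the same limit of the test and give no numbers: the limit of > 10000 nM in this assay, at which 3 of the 3 values shown sit.

The compounds shown leave open where each one truly stands beyond that limit, and whether exchanging 2-methoxy-5-methylphenyl for 3-chloro-2-methylphenyl changes the read-out at all.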